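Indole Amide Truncation on a Pyrimidinone Core

The compounds below may be only part of what the source reports. "The series", "measured", "known", "first", "only" and "open" are said of these compounds alone.

Measured compounds:
compound 1 `CC[C@@H]1C(=O)N(C)c2cnc(Nc3ccc(S(N)(=O)=O)cc3)nc2N1C1CCCC1` — 1300 nM
compound 2 `CCC1C(=O)N(C)c2cnc(-n3ccc4cc(C(=O)NC(C)C)ccc43)nc2N1c1ccn(C)n1` — 6740 nM
compound 3 `CC[C@@H]1C(=O)N(C)c2cnc(-n3ccc4cc(C(=O)NCC(C)C)ccc43)nc2N1C1CCCC1` — "not active" (no number reported)

In a functional assay on Huh-7 cells (Homo sapiens) for antiproliferative activity, read by CCK-8 assay, with a stated time of 72 h (on this read-out higher numbers stand for weaker inhibition of growth and lower numbers for stronger inhibition of growth), compound 1 gives 1300 nM. Compound 2 gives 6740 nM in this assay. Compound 3 has no number in this assay; it is reported only as "not active" (no number reported), so it stands below both measured compounds without a stated value. Compound 4 `CC[C@@H]1C(=O)N(C)c2cnc(-n3ccc4cc(C(N)=O)ccc43)nc2N1C1CCCC1` differs from compound 3 by hydrogen in place of isobutyl on an amide-type nitrogen. Going by the values given here, no measured pair shows this change, so its size is unknown; since compound 3 gave no number, any measurable result for compound 4 in this assay would be a move toward stronger inhibition, though compound 2 suggests this indole series stays weak. Compound 4 is expected to give about 8000 nM, estimated between 2000 nM and 40000 nM.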

Compound 4, concentration for 50% growth inhibition: 3090 nM
Beside the measured number, compound 4's estimate is 2.6-fold (0.41 log units) above it, and the stated range covers the measured number.
By their numbers in this assay, from the lowest: compound 1; then compound 4; then compound 2.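

Going by these compounds alone, compound 3 has no number in this assay, and no step from it to compound 4 can be read. The compounds shown leave open how large the change from isobutylcarbamoyl to carbamoyl is. No evidence bears on this result.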